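A few compounds are considered here, and "the series" means these few. Any claim that something is new, unique, unknown or untested is made for them only; others in the source may bear on it.

Working notes on the series. Compound 1 `CC(=O)Nc1ccc(-c2nc3cc([N+](=O)[O-])ccc3[nH]2)cc1`, compound 2 `CC(=O)Nc1ccc(-c2nc3ccccc3[nH]2)cc1` and compound 3 `O=[N+]([O-])c1ccc(-c2nc3ccccc3[nH]2)c([N+](=O)[O-])c1` have been tested in an ADME assay on BHK cells (Mesocricetus auratus) for cytotoxicity, read by MTT assay, with a stated time of 96 h; on this read-out lower numbers stand for higher toxicity in this test and higher numbers for lower toxicity in this test. For compound 1 the result is only a limit of the assay, > 100000 nM. For compound 2 the result is likewise a limit, > 100000 nM. For compound 3 the result is again a limit, > 100000 nM. The change from compound 1 to compound 2 is hydrogen in place of nitro on an aromatic carbon, and the step that the two limits leave unreadable from compound 1 to compound 2 cannot be read because of the limit of > 100000 nM in this assay, at which 3 of the 3 values shown sit. How the cores of compound 1 and compound 3 differ is not broken down here.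

Compound 4 `O=[N+]([O-])c1ccccc1-c1nc2ccccc2[nH]1` is still to be measured in this assay. It arises from compound 3 by hydrogen in place of nitro on an aromatic carbon, the same kind of change as that from compound 1 to compound 2, though the place differs: there it sat on a ring that is part of a fused or bridged system of two rings, meta to a fused ring and para to a fused ring, here on a ring of carbon only, meta to a nitro group and para to a group of 9 heavy atoms. For the measured compounds named here, since every value so far sits at the limit of > 100000 nM in this assay, at which 3 of the 3 values shown sit, the step from compound 3 to compound 4 is expected to be a step that the limit leaves unreadable from compound 3 to compound 4, with compound 4 most likely again reported only as a limit. The estimate for compound 4 in this assay is 150000 nM, between 70000 nM and 400000 nM.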

Compound 4, half-maximal cytotoxic concentration: > 100000 nM
Compound 4 ended at the assay's limit (the forecaster's own chance of this, stated with the estimate: 85%); the middle value lies beyond the limit too.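

For the compounds shown here, compound 4, like compound 3, gives only a limit, so no step between them can be read: the limit of > 100000 nM in this assay, at which 4 of the 4 values shown sit. The compounds shown leave open whether in this assay hydrogen in place of nitro changes the read-out at all.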